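Dropping Two Chlorines From a Benzyl Ether

The source may hold more compounds than are shown below. What is called first, only, known or untested is meant among the compounds shown, and "the series" means these compounds.

Going by the values given here, the three compounds measured so far share one core and were tested in a functional assay on BEL-7404 cells (Homo sapiens) for cytotoxicity, read by MTT assay, with a stated time of 72 h; a higher number here means a weaker inhibitor, a lower number a stronger inhibitor. Compound 1 `COCOc1cc(/C=C/C(=O)OCC(=O)Nc2ccc(Cl)cc2)ccc1OCc1ccccc1` returns only a limit of the assay, > 200000 nM. Compound 3 `CCOc1ccc(COc2c(OC)cc(/C=C/C(=O)OCC(=O)Nc3ccccc3)cc2OC)cc1` likewise returns only a limit, > 200000 nM. Among the compounds with values here, compound 2 `COc1ccc(NC(=O)COC(=O)/C=C/c2cc(OC)c(OCc3ccc(Cl)c(Cl)c3)c(OC)c2)cc1` is the one compound with a number rather than a limit, giving 97800 nM, so it is the only readable point in the set. The other two values sit at the limit of > 200000 nM in this assay, at which 2 of the 3 values shown sit.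

Compound 4 `COc1ccc(NC(=O)COC(=O)/C=C/c2cc(OC)c(OCc3ccccc3)c(OC)c2)cc1` has not yet been measured. It differs from compound 2 in one place: phenyl in place of 3,4-dichlorophenyl on a saturated chain carbon bound to an oxygen on an aromatic ring. Within the data shown here, no step between measured compounds shows what taking the two chlorines off this benzyl group does, so no measured guide exists for the size of the change. Still, a move toward weaker inhibition is expected because compound 1 and compound 3, the two compounds without chlorine on that benzyl ring, both sit at the limit of > 200000 nM in this assay, at which 2 of the 3 values shown sit. The step expected is a 1.8-fold higher number from compound 2 to compound 4 (0.26 log units; within the scatter), likely beyond the usual scatter. Compound 4 is therefore expected to give about 180000 nM, within a range from 80000 nM to 400000 nM, with a real chance that the assay reports only a limit and no number.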

Compound 4, half-maximal inhibitory concentration: > 200000 nM
Compound 4 gave a limit, no number; the forecaster's own chance of this, stated with the estimate: 50%; middle value at least 1.1-fold (0.04 log units) from the limit.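

In this assay, going by these compounds alone, replacing 3,4-dichlorophenyl with phenyl on this benzyl ether gives an at least 2.0-fold higher number from compound 2 to compound 4 (0.31 log units; beyond the scatter), the first measured step at this position. Within this pair, the two chlorines are what separate a readable number from no number, so the one measurable result in the set depends on them here. The full size of the step remains unknown, because compound 4 gives only a limit, as do most of the compounds shown: the limit of > 200000 nM in this assay, at which 3 of the 4 values shown sit.

The compounds shown leave open whether a single chlorine on this ring would be enough to keep a readable number, and whether a bromine atom, a methyl group or a trifluoromethyl group could take the place of the chlorines. Within the data shown here, they also leave open whether removing the chlorines would have the same result with a different group on the amide nitrogen, as no other pair here differs only in this benzyl ring.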